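Moving a Methyl Group Around a Benzamide Ring

This account rests on a few compounds, and the source may have more. Where it says the series, first, only, none or still open, it means among the compounds named here.

Of the compounds shown here, three sharing one core have been tested in a functional assay on MDA-MB-231 cells (Homo sapiens) for antiproliferative activity, read by CCK-8 assay, with a stated time of 72 h; a higher number here means a weaker inhibitor, a lower number a stronger inhibitor. Compound 1 `O=C(Nc1cccc(-c2oc3cc(-c4ccc(F)cc4)ccc3c(=O)c2O)c1)c1ccc(F)cc1` carries a fluoro on its benzamide ring and gives 16000 nM. Compound 2 `Cc1ccc(C(=O)Nc2cccc(-c3oc4cc(-c5ccc(F)cc5)ccc4c(=O)c3O)c2)cc1` has a methyl in that place and gives 4350 nM. Compound 3 `O=C(Nc1cccc(-c2oc3cc(-c4ccc(F)cc4)ccc3c(=O)c2O)c1)c1ccc(C(F)(F)F)cc1` has a trifluoromethyl there and gives 29400 nM. Compound 2 therefore stands lowest of the three, so it is the strongest inhibitor in this set; the step of a 3.7-fold lower number from compound 1 to compound 2 (0.57 log units; beyond the scatter) and the step of a 6.8-fold higher number from compound 2 to compound 3 (0.83 log units; beyond the scatter) both lie beyond the scatter, while the step of a 1.8-fold higher number from compound 1 to compound 3 (0.26 log units; within the scatter) does not.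

Compound 4 `Cc1cccc(C(=O)Nc2cccc(-c3oc4cc(-c5ccc(F)cc5)ccc4c(=O)c3O)c2)c1` is the next in line. It differs from compound 2 by 3-methylphenyl in place of 4-methylphenyl on a carbonyl carbon; the same atoms are present, only arranged differently. The measured steps all swap one group for another in the same position, so none of them directly tests a shift of the methyl within the ring. They do show that the methyl is the most favourable of the three groups tried, which suggests compound 4 should stay in the same region as compound 2, possibly somewhat weaker. The expected change is a 1.5-fold higher number from compound 2 to compound 4 (0.17 log units; within the scatter). Compound 4 is expected to give about 6500 nM, most likely between 2500 nM and 17000 nM.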

Compound 4, half-maximal inhibitory concentration: 2840 nM
Compound 4: middle estimate off by 2.3-fold (0.36 log units), on the high side; the measured number falls inside the stated range.
By their numbers in this assay, from the lowest: compounds 4 and 2 (each within the scatter of the next); then compounds 1 and 3 (each within the scatter of the next).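

Moving the methyl from 4-methylphenyl to 3-methylphenyl on the carbonyl carbon is the first change here that rearranges the same atoms instead of swapping one group for another. In this assay it gives a 1.5-fold lower number from compound 2 to compound 4 (0.19 log units; within the scatter) and so the two arrangements cannot be told apart, while compound 4 stays clearly separated from the other two compounds, with a 5.6-fold lower number from compound 1 to compound 4 (0.75 log units; beyond the scatter) and a 10-fold lower number from compound 3 to compound 4 (1.02 log units; beyond the scatter) showing that both methyl compounds sit apart from the fluoro and trifluoromethyl compounds, whichever of these two arrangements the methyl takes. No measurement at hand accounts for why the compounds fall in this order.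

On these data alone, it remains open whether a longer chain such as ethyl or propyl, a methoxy group or an amine on this ring would hold the level of compound 2 and compound 4. As far as these compounds go, it also remains open whether a plain phenyl with no added group would do as well, which would show whether the methyl itself matters at all.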